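A few compounds are considered here, and "the series" means these few. Any claim that something is new, unique, unknown or untested is made for them only; others in the source may bear on it.

In an ADME assay on MRC5 cells (Homo sapiens) for inhibition, with a stated time of 72 h (on this read-out higher numbers stand for an effect only at larger amounts of compound and lower numbers for an effect already at smaller amounts), compound 1 `COc1cccc(OC)c1C(=O)Nc1c[nH]nc1C(=O)NC1CCCCCC1` gives 42000 nM, and compound 2 `COc1cccc(OC)c1C(=O)Nc1c[nH]nc1C(=O)NC1CCC(C)CC1` gives 45000 nM. Among the compounds with values here, these are the only two numbers so far and they lie within the scatter of each other, so compound 2 stands level with compound 1. Compound 3 `COc1cccc(OC)c1C(=O)Nc1c[nH]nc1C(=O)NC1CCCCC1` differs from compound 2 by one small edit: hydrogen in place of methyl on a saturated ring carbon. In words, this is hydrogen in place of methyl on a saturated ring carbon, which turns 4-methylcyclohexyl into cyclohexyl. Within the data shown here, one measured step bears on this edit: a 1.1-fold higher number from compound 1 to compound 2 (0.03 log units; within the scatter), with 4-methylcyclohexyl in place of cycloheptyl on an amide-type nitrogen. Among the measured compounds shown here, that step is a different change and only a single example, so it is a rough guide. On that evidence, no step beyond the scatter is expected in this assay, in either direction. The expected step is a 1.1-fold lower number from compound 2 to compound 3 (0.04 log units; within the scatter). Compound 3 is estimated at 41000 nM, with an expected range of 20000 nM to 80000 nM.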

Compound 3, half-maximal effective concentration: 35000 nM
Estimate against measurement, compound 3: 1.2-fold (0.07 log units) above; the measured number falls inside the stated range.
By their numbers in this assay, from the lowest: compounds 3, 1 and 2 (each within the scatter of the next).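

Taking the methyl off the saturated ring carbon leaves the read-out in this assay within the scatter (a 1.3-fold lower number from compound 2 to compound 3 (0.11 log units; within the scatter)), so this methyl, three ring bonds from the ring atom that bears a large group, has no effect that can be told apart here. Compound 3 also shows that the plain six-membered ring and the seven-membered ring cannot be separated (a 1.2-fold lower number from compound 1 to compound 3 (0.08 log units; within the scatter)), which means cycloheptyl, 4-methylcyclohexyl and cyclohexyl on the amide-type nitrogen all read alike. Nothing in the data shown explains this lack of difference.

All three compounds carry a saturated ring of carbon only on that nitrogen. As far as these compounds go, how an amine or a carboxylic acid on this ring, or a phenyl ring in its place, would read in this assay stays open.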